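The source may report more compounds than this note shows. Statements on the series, on what has been measured and on what is new or still open speak of the compounds shown alone.

The series rests on a shared core: compound 1 `Clc1ccc2[nH]c(SCc3ccccc3CCc3ccccc3)nc2c1`, compound 2 `[O-][S+](Cc1ccccc1)c1ccccc1CSc1nc2cc(Cl)ccc2[nH]1` and compound 3 `Clc1ccc2[nH]c(SCc3ccccc3C#Cc3ccccc3)nc2c1` differ only in the group attached to one aromatic carbon. In an assay on isolated protein for inhibition of Indoleamine 2,3-dioxygenase 1 (Homo sapiens), with a stated time of 60 min, tested at 10 uM (a higher number here means more inhibition at the concentration tested (going by the name of the read-out), a lower number less inhibition), compound 3 gives 52%, the highest of the three numbers, though its margin over compound 1 is within the scatter: compound 1 gives 47%, and the change from compound 1 to compound 3 was a number 5 percentage points higher from compound 1 to compound 3 (within the scatter). Compound 2 gives 11%, and the steps to and from it are large: a number 36 percentage points lower from compound 1 to compound 2 (beyond the scatter) and a number 41 percentage points higher from compound 2 to compound 3 (beyond the scatter).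

Compound 4 `Clc1ccc2[nH]c(SCc3ccccc3OCc3ccccc3)nc2c1` has not yet been measured. Relative to compound 3 the change is benzyloxy in place of 2-phenylethynyl on an aromatic carbon.

The step from compound 1 to compound 3 lies within the scatter, while the two steps involving compound 2 show that the group holding oxygen and sulfur went with a sharply lower read-out. Benzyloxy, unlike 2-phenylethynyl, contains oxygen, as the group in compound 2 does, though without sulfur; a moderate downward step, smaller than that to compound 2, is therefore expected in this assay: a number 12 percentage points lower from compound 3 to compound 4 (beyond the scatter). Compound 4 is accordingly estimated at 40%, with a range from 15% to 60%.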

Compound 4, a percentage reported as inhibition, at one concentration (the size of the read-out at that concentration, not a potency): 3%
Estimate against measurement, compound 4: 37 percentage points above; the whole stated range lies above it.
By their numbers in this assay, from the lowest: compounds 4 and 2 (each within the scatter of the next); then compounds 1 and 3 (each within the scatter of the next).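

In this assay, the exchange of 2-phenylethynyl for benzyloxy at this aromatic carbon, ortho to a large group, gives a number 49 percentage points lower from compound 3 to compound 4 (beyond the scatter), and the comparison with the phenethyl compound gives a number 44 percentage points lower from compound 1 to compound 4 (beyond the scatter), so a group with the same count of 8 heavy atoms and the same aromatic ring does not keep the read-out at this position. The step of a number 8 percentage points lower from compound 2 to compound 4 (within the scatter) lies within the scatter, which shows that a low read-out here does not require the sulfur of compound 2: among these four compounds, the two groups holding oxygen give low numbers and the two all-carbon groups give higher ones, and none goes against this. The data give no measured basis for explaining this difference between the groups.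

As far as these compounds go, what remains open is whether the oxygen itself goes with the loss or whether any group other than the all-carbon ones would do the same, which a benzylamino group, with nitrogen in place of the oxygen, or a benzylthio group, with sulfur alone, could test. A phenoxymethyl group, holding the same atoms in another order, would also show whether the placing of the oxygen matters.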